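A few compounds are considered here, and "the series" means these few. Any claim that something is new, unique, unknown or untested is made for them only; others in the source may bear on it.

Measured in a functional assay on MCF7 cells (Homo sapiens) for cytotoxicity, read by MTT assay, with a stated time of 72 h; a higher number here means a weaker inhibitor, a lower number a stronger inhibitor:
compound 1 `O=C1c2c[n+]([O-])c3ccccc3c2C(=O)c2c1c1ccccc1n2Cc1cn([C@H]2C[C@H](O)[C@@H](CO)O2)nn1`: 530 nM
compound 2 `O=C1c2c[n+]([O-])c3ccccc3c2C(=O)c2c1c1ccccc1n2Cc1cn([C@@H]2C[C@H](O)[C@@H](CO)O2)nn1`: 110 nM
compound 3 `O=C1c2c[n+]([O-])c3ccccc3c2C(=O)c2c1c1ccccc1n2CCCCN1CCCCC1`: 150 nM

Compound 2 stands lowest of the three numbers; compound 3 sits within the scatter of it, while compound 1 lies beyond it, by a 4.8-fold lower number from compound 1 to compound 2 (0.68 log units; beyond the scatter). That step rests on (the fact that compounds 1 and 2 differ only in the configuration as drawn), so the sugar's configuration alone shifts this assay modestly.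

Compound 4 `O=C1c2c[n+]([O-])c3ccccc3c2C(=O)c2c1c1ccccc1n2Cc1cn([C@@H]2O[C@H](CO)[C@@H](O)[C@H](O)[C@H]2O)nn1` differs from compound 2 by 3,4,5-trihydroxy-6-(hydroxymethyl)oxan-2-yl in place of 4-hydroxy-5-(hydroxymethyl)oxolan-2-yl on an aromatic nitrogen. Among the compounds with values here, no measured step swaps the sugar ring itself; only the configurational step from compound 1 to compound 2 touches that part, and it was modest. The change is therefore expected to move this assay little, at most a modest rise, a 2.7-fold higher number from compound 2 to compound 4 (0.44 log units; beyond the scatter).

Compound 4 is estimated at 300 nM, between 90 nM and 1000 nM.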

Compound 4, half-maximal inhibitory concentration: 590 nM
Compound 4: middle estimate off by 2.0-fold (0.29 log units), on the low side; the measured number falls inside the stated range.
By their numbers in this assay, from the lowest: compounds 2 and 3 (each within the scatter of the next); then compounds 1 and 4 (each within the scatter of the next).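

In this assay, 3,4,5-trihydroxy-6-(hydroxymethyl)oxan-2-yl in place of 4-hydroxy-5-(hydroxymethyl)oxolan-2-yl on the aromatic nitrogen gives a 5.4-fold higher number from compound 2 to compound 4 (0.73 log units; beyond the scatter), a step that swaps the sugar ring itself. The same exchange gives a 1.1-fold higher number from compound 1 to compound 4 (0.05 log units; within the scatter), so the size of the step depends on the configuration of the sugar it starts from, and that configuration is the only difference between the two starting compounds: the fact that compounds 1 and 2 differ only in the configuration as drawn

The compounds shown leave open how a simple amine or a carboxylic acid in place of the sugar would read, and how another configuration of the six-membered sugar would compare with compound 4.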